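The source may hold more compounds than are shown below. What is called first, only, known or untested is meant among the compounds shown, and "the series" means these compounds.

Measured so far:

Compound 1 `COC1=CC(=O)c2c(c(COC(=O)c3ccccc3F)cn2C)C1=O`: 500 nM
Compound 2 `COC1=CC(=O)c2c(c(COC(=O)c3ccc(F)cc3)c(C)n2C)C1=O`: 27000 nM
Compound 3 `COC1=CC(=O)c2c(c(COC(=O)c3ccccc3)c(C3CC3)n2C)C1=O`: 198000 nM

In a functional assay on V79-379A cells (Cricetulus griseus) for cytotoxicity, read by MTT assay, in the presence of a further agent that is not named here (a higher number here means a weaker inhibitor, a lower number a stronger inhibitor), compound 2 gives 27000 nM, the second highest of these three numbers; compound 3 sits closest to it, and compound 1 lies farthest away, with the lower number. No pair among these three differs in only one place, so the measured numbers alone give no single-change step to lean on.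

Compound 4 `COC1=CC(=O)c2c(c(COC(N)=O)c(C)n2C)C1=O` arises from compound 2 by one change: amino in place of 4-fluorophenyl on a carbonyl carbon. Going by the values given here, no measured pair shows this kind of exchange, and the other two compounds differ from compound 2 in more than one place. The step from compound 2 to compound 4 is therefore expected to be small, a 1.3-fold higher number from compound 2 to compound 4 (0.11 log units; within the scatter), likely within the scatter. Compound 4 is estimated at 35000 nM, with a range from 8000 nM to 150000 nM.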

Compound 4, half-maximal inhibitory concentration: 25000 nM
Estimate against measurement, compound 4: 1.4-fold (0.15 log units) above; the measured number falls inside the stated range.
By their numbers in this assay, from the lowest: compound 1; then compounds 4 and 2 (each within the scatter of the next); then compound 3.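

Replacing 4-fluorophenyl with amino on the carbonyl carbon removes a whole aromatic ring, yet in this assay the step is a 1.1-fold lower number from compound 2 to compound 4 (0.03 log units; within the scatter). At this position, with the rest of compound 2 unchanged, the aromatic ring is therefore not needed to keep this level of cytotoxicity. No measurement available here explains why the two groups read alike. On these data alone, whether a methylamino or dimethylamino group on the same carbonyl carbon would also read alike remains open. So does whether amino would behave the same way on the core of compound 1.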